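The compounds below may be only part of what the source reports. "The series", "measured", "known", "first", "only" and "open" are said of these compounds alone.

The three measured compounds share one core. Compound 1 `O=C(COCc1ccccc1)N1CCN(c2ccccn2)CC1` gives 5400 nM in a functional assay on HEK293 cells for positive allosteric modulation of metabotropic glutamate receptor 5 (Rattus norvegicus), read by fluorescence and calcium flux; on this read-out higher numbers stand for an effect only at larger amounts of compound and lower numbers for an effect already at smaller amounts. Compound 2 `O=C(COCc1ccccc1)N1CCN(c2cccnc2)CC1` is recorded in this assay as "not active" (no number reported), with no number attached. Compound 3 `O=C(COCc1ccccc1)N1CCN(c2ccccc2Cl)CC1` gives 820 nM in this assay, the lowest of the two numbers; the step of a 6.6-fold lower number from compound 1 to compound 3 (0.82 log units; beyond the scatter) lies beyond the scatter, and compound 2 stands apart without a number. Compound 4 `O=C(COCc1ccccc1)N1CCN(c2ccccc2[N+](=O)[O-])CC1` has not yet been measured. It differs from compound 3 in one place: nitro in place of chloro on an aromatic carbon. For the measured compounds named here, only one measured step exists, a 6.6-fold lower number from compound 1 to compound 3 (0.82 log units; beyond the scatter), and it exchanged a whole ring rather than one group on an aromatic carbon, so it bears only loosely on this change. Nothing measured here tells whether nitro in place of chloro on an aromatic carbon moves the number at all. The expected step is therefore a 1.8-fold higher number from compound 3 to compound 4 (0.26 log units; within the scatter), one that is likely to stay within the scatter, with the wider range allowing a modest rise. Compound 4 is estimated at 1500 nM, with a range from 400 nM to 6000 nM.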

Compound 4, half-maximal effective concentration: 1800 nM
Compound 4: middle estimate off by 1.2-fold (0.08 log units), on the low side; the measured number falls inside the stated range.
By their numbers in this assay, from the lowest: compound 3; then compound 4; then compound 1.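

In this assay, the exchange of nitro for chloro on an aromatic carbon ortho to a large group gives a 2.2-fold higher number from compound 3 to compound 4 (0.34 log units; beyond the scatter), a modest step. For the compounds shown here, the one earlier step exchanged a whole ring, whereas this one changes a single group on the ring and keeps the ring itself, showing that the group at this place alone moves the number, with chloro giving the lower number of the two. Nothing measured here accounts for this difference between chloro and nitro.

On these data alone, it remains open whether another group at this place, such as a methoxy, an amine or a nitrile, would give a number lower than chloro does. Also open, as far as these compounds go, is whether chloro or nitro on another carbon of the same ring would give a similar number.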